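A Chlorophenyl Swap on an Adenosine Receptor Ligand

The compounds below may be only part of what the source reports. "The series", "measured", "known", "first", "only" and "open" are said of these compounds alone.

Of the compounds shown here, three have been tested in an assay on CHO cells for displacement of a labelled ligand from adenosine receptor A3 (Homo sapiens), read by scintillation counting, with a stated time of 3 h; on this read-out higher numbers stand for weaker inhibition and lower numbers for stronger inhibition. Compound 1 `Cn1c(-c2cccnc2)nc2c(NC3CCCC3)ncnc21` gives 11000 nM, the highest number of the three. Compound 2 `CCCn1c(-c2ccccc2)nc2c(N)ncnc21` gives 9280 nM, which lies within the usual scatter of compound 1, so the two cannot be told apart. Compound 3 `Cn1c(-c2ccccc2)nc2c(NC3CCCCC3)ncnc21` gives 2370 nM, a clearly lower number than compound 1, though it differs from compound 1 in more than one place, so no single cause can be read from it. Compound 4 `Cn1c(-c2ccccc2Cl)nc2c(NC3CCCC3)ncnc21` has not yet been measured. It differs from compound 1 in one place: 2-chlorophenyl in place of pyridin-3-yl on an aromatic carbon. Going by the values given here, compound 4 is expected to give a lower number, with a step of a 2.8-fold lower number from compound 1 to compound 4 (0.44 log units; beyond the scatter) estimated, though the data give no single step to lean on. Compound 4 is therefore estimated at 4000 nM, in a range from 1500 nM to 12000 nM.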

Compound 4, inhibition constant: 720 nM
Compound 4: middle estimate off by 5.6-fold (0.74 log units), on the high side; measured number below the stated range.
By their numbers in this assay, from the lowest: compound 4; then compound 3; then compounds 2 and 1 (each within the scatter of the next).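

Placing 2-chlorophenyl instead of pyridin-3-yl on the aromatic carbon between two ring nitrogen atoms gives a 15-fold lower number from compound 1 to compound 4 (1.18 log units; beyond the scatter) in this assay, showing that this position strongly affects the read-out. The change removes the ring nitrogen and adds chlorine together, so the step cannot be divided between them. No measurement shown explains the step.

Plain phenyl at this position on the core of compound 1 would help separate those two parts. A phenyl ring carrying methoxy instead of chlorine would show whether chlorine itself matters.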